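Cyclopropylcarbamoyl for 4-fluorophenyl in the semicarbazide series

The source may report more compounds than this note shows. Statements on the series, on what has been measured and on what is new or still open speak of the compounds shown alone.

Three members of the series have been measured in a functional assay on CHO cells for antagonist activity at sphingosine 1-phosphate receptor 2 (Homo sapiens), read by fluorescence and calcium flux, with a stated time of 3 min; on this read-out higher numbers stand for weaker inhibition and lower numbers for stronger inhibition. Compound 1 `Cc1cc(C#N)nc(NNC(=O)Nc2cc(Cl)nc(Cl)c2)c1` gives only a limit of the assay, > 6600 nM. Compound 2 `CCOC(=O)c1cc(C)cc(NNC(=O)Nc2cc(Cl)nc(Cl)c2)n1` gives 760 nM, and compound 3 `Cc1cc(NNC(=O)Nc2cc(Cl)nc(Cl)c2)nc(-c2ccc(F)cc2)c1` gives 1300 nM. The two steps from the nitrile are both beyond the scatter: an at least 8.6-fold lower number from compound 1 to compound 2 (0.93 log units; beyond the scatter) and an at least 5.0-fold lower number from compound 1 to compound 3 (0.70 log units; beyond the scatter). Between the two numbers, a 1.7-fold higher number from compound 2 to compound 3 (0.23 log units; within the scatter), so compound 3 holds the higher of the two numbers shown, but its gap to compound 2 is within the scatter; the third value is only a limit, for which the limit of > 6600 nM in this assay, at which 1 of the 3 values shown sits, is the relevant bound.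

Compound 4 `Cc1cc(NNC(=O)Nc2cc(Cl)nc(Cl)c2)nc(C(=O)NC2CC2)c1` differs from compound 3 in one place: cyclopropylcarbamoyl in place of 4-fluorophenyl on an aromatic carbon. Within the data shown here, no measured step swaps an aryl for a carbamoyl. The nearest guide is the swap of ethoxycarbonyl for 4-fluorophenyl, which stayed within the scatter, and both carbonyl-bearing groups sit on the same aromatic carbon; cyclopropylcarbamoyl shares the carbonyl with the ethoxycarbonyl of compound 2 and its value 760 nM. A step no larger than the scatter is therefore expected for a 1.4-fold lower number from compound 3 to compound 4 (0.16 log units; within the scatter), if anything towards a lower number. Compound 4 is expected to give about 900 nM, between 300 nM and 2700 nM.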

Compound 4, half-maximal inhibitory concentration: 4500 nM
The estimate for compound 4 lay 5.0-fold (0.70 log units) below the measured number; the measured number lies above the stated range.
By their numbers in this assay, from the lowest: compounds 2 and 3 (each within the scatter of the next); then compound 4. At a limit, above all of these: compound 1.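

On the aromatic carbon next to the ring nitrogen, the ethoxycarbonyl and the 4-fluorophenyl lay within the scatter of each other, whereas in this assay the cyclopropylcarbamoyl separates from both, with a 3.5-fold higher number from compound 3 to compound 4 (0.54 log units; beyond the scatter), and a 5.9-fold higher number from compound 2 to compound 4 (0.77 log units; beyond the scatter). The second of these steps keeps the carbonyl in place and exchanges only ethoxy for cyclopropylamino, so a carbonyl on this carbon is not enough on its own to hold the number at the level of compound 2. The comparison with the nitrile, an at least 1.4-fold lower number from compound 1 to compound 4 (0.16 log units; that floor lies within the scatter), gives no order between the two compounds, and compound 1 is held only at a limit of the assay: the limit of > 6600 nM in this assay, at which 1 of the 4 values shown sits.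

The compounds shown do not tell whether the higher number goes with the amide hydrogen or with the cyclopropyl ring, a question that a dimethylcarbamoyl group and a plain carbamoyl group on the same carbon would separate. As far as these compounds go, how a carboxylic acid or an aminomethyl group would read at this position also remains open.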